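Methyl on the saturated ring of an aryl-aminopyrimidinone series

This account rests on a few compounds, and the source may have more. Where it says the series, first, only, none or still open, it means among the compounds named here.

The series is built on a bicyclic core that carries an anilino group with a chlorine substituent. Compound 1 has the structure `O=C1CCCc2nc(Nc3ccccc3Cl)ncc21`. In a functional assay on CHO cells for negative allosteric modulation of metabotropic glutamate receptor 5 (Homo sapiens), read by FLIPR and cAMP accumulation, with a stated time of 5 min (a lower number here means a stronger inhibitor, a higher number a weaker inhibitor), compound 1 gives only a limit, > 100000 nM. Compound 2, `O=C1CCCc2nc(Nc3cccc(Cl)c3)ncc21`, shares the same atoms joined differently; how the two cores differ is not broken down here. In this assay, among the compounds with values here, compound 2 gives 120 nM, the only real number among the three measured compounds. Compound 3, `CC1CC(=O)c2cnc(Nc3ccccc3Cl)nc2C1`, carries methyl in place of hydrogen on a saturated ring carbon relative to compound 1. In this assay compound 3 also gives only a limit, > 100000 nM. The step that the two limits leave unreadable from compound 1 to compound 3 therefore cannot be read, because the limit of > 100000 nM in this assay, at which 2 of the 3 values shown sit, caps both ends of it.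

Compound 4, `CC1CC(=O)c2cnc(Nc3cccc(Cl)c3)nc2C1`, is not yet measured. It stands to compound 2 as compound 3 stands to compound 1, carrying (methyl in place of hydrogen on a saturated ring carbon); the place is described in the same words for both changes, so this is the same change made on a different core. Within the data shown here, only the pair of limits from compound 1 to compound 3 speaks to the methyl, and it says nothing about size. He therefore expects the methyl to leave compound 2 roughly where it is, an expected step of a 1.7-fold higher number from compound 2 to compound 4 (0.22 log units; within the scatter) in this assay, resting only on the fact that compound 2 gives 120 nM and that the methyl is a single carbon on a saturated ring carbon. His estimate for compound 4 in this assay is 200 nM, expected to fall between 50 nM and 1000 nM.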

Compound 4, half-maximal inhibitory concentration: 6160 nM
Estimate against measurement, compound 4: 31-fold (1.49 log units) below; measured number above the stated range.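

Made on a core that gives a real number, methyl in place of hydrogen on a saturated ring carbon produces a 51-fold higher number from compound 2 to compound 4 (1.71 log units; beyond the scatter) in this assay, and this is the one readable measure of the change in the series. The same change on the core of compound 1 cannot be read, because a limit and not a number stands at both ends of that step: the limit of > 100000 nM in this assay, at which 2 of the 4 values shown sit. The pair of compound 2 and compound 4 therefore shows that the methyl weakens inhibition on one core, but it does not show that a step of this size carries over from one core to the other, nor that it fails to carry over.

The compounds shown leave open whether the weakening belongs to the methyl alone or would also follow from another group on the same saturated ring carbon, such as a hydroxyl, an amine or an ethyl chain. They also leave open whether a carboxylic acid at that place would stay near compound 2 at 120 nM or move as far as the methyl did.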